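Changing the Group on the Saturated Chain Carbon

This account rests on a few compounds, and the source may have more. Where it says the series, first, only, none or still open, it means among the compounds named here.

Measured compounds:
compound 1 `CCC(NC(=O)C(CC(C)C)NC(=O)OCc1ccccc1)C(=O)C(=O)NCC1(C)CC(O)CC(C)(C)C1` — 69 nM
compound 2 `CCC(NC(=O)C(CC(C)C)NC(=O)OCc1ccccc1)C(=O)C(=O)NCc1cccnc1` — 120 nM

In an assay on isolated protein (Oryctolagus cuniculus) for inhibition of Calpain-2 catalytic subunit (Homo sapiens) (on this read-out higher numbers stand for weaker inhibition and lower numbers for stronger inhibition), compound 1 gives 69 nM, and compound 2 gives 120 nM; the two lie within the scatter of each other. Compound 3 `CCC(NC(=O)C(CC(C)C)NC(=O)OCc1ccccc1)C(=O)C(=O)NCCCN1CCc2ccccc2C1` carries a group of 12 heavy atoms (11 carbon, 1 nitrogen; one six-membered non-aromatic ring with 1 hetero atom, one six-membered aromatic ring of carbon only) in place of a group of 10 heavy atoms (9 carbon, 1 oxygen; one six-membered non-aromatic ring of carbon only), on a saturated chain carbon bound to an amide-type nitrogen. Among the measured compounds shown here, the only step that bears on this position, a 1.7-fold higher number from compound 1 to compound 2 (0.24 log units; within the scatter), stayed within the scatter, so the group at this site appears tolerant of exchange; a step of similar size, or none beyond the scatter, is expected for a 1.4-fold higher number from compound 1 to compound 3 (0.16 log units; within the scatter). Compound 3 is therefore estimated at 100 nM, with a range from 30 nM to 350 nM.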

Compound 3, inhibition constant: 190 nM
Compound 3: middle estimate off by 1.9-fold (0.28 log units), on the low side; measured number inside the range.
By their numbers in this assay, from the lowest: compounds 1, 2 and 3 (each within the scatter of the next, the first and the last beyond it).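

In this assay, among the compounds shown here, 2-(1,2,3,4-tetrahydroisoquinolin-2-yl)ethyl in place of the group of compound 1 gives a 2.8-fold higher number from compound 1 to compound 3 (0.44 log units; beyond the scatter), the only step at this position beyond the scatter, so tolerance of exchange here has a modest limit. Against the pyridin-3-yl group, the same change gives a 1.6-fold higher number from compound 2 to compound 3 (0.20 log units; within the scatter), which does not separate the two groups. No available measurement accounts for the step. From the compounds shown here alone, it remains open whether a plain benzyl group, a longer alkyl chain or a carboxylic acid on this saturated chain carbon would stay within the scatter of compound 1.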